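A few compounds are considered here, and "the series" means these few. Any claim that something is new, unique, unknown or untested is made for them only; others in the source may bear on it.

Series notes. Compound 1 `Nc1cccc(-c2cn3nc(Cc4ccccc4)sc3n2)c1` and compound 2 `Nc1cccc(-c2cn3nc(Cc4ccc(Cl)cc4)sc3n2)c1` share one core; compound 3 `Nc1cccc(-c2cn3c(-c4ccc(Cl)cc4)csc3n2)c1` carries a second core, and the difference between the two cores is not broken down here. In a functional assay on CCRF-CEM cells (Homo sapiens) for inhibition, read by cell counting, with a stated time of 3 days (on this read-out higher numbers stand for weaker inhibition and lower numbers for stronger inhibition), compound 1 gives 37000 nM, compound 2 gives 42000 nM, and compound 3 gives 21000 nM. All three values lie within the usual scatter of one another, so no order among the three is drawn from them.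

Compound 4 `Nc1cccc(-c2cn3c(-c4ccccc4)csc3n2)c1` has not yet been measured. From compound 3 to compound 4 the change is hydrogen in place of chloro on an aromatic carbon. The same change appears once more in the set, from compound 2 to compound 1, namely (hydrogen in place of chloro on an aromatic carbon), where it gave a 1.1-fold lower number from compound 2 to compound 1 (0.06 log units; within the scatter). The two occurrences sit on different cores, but the surroundings of the place are described in identical words for both, so the change is taken as the same one rather than merely a change of the same kind.

Expectation for compound 4 in this assay: the step is estimated at a 1.1-fold lower number from compound 3 to compound 4 (0.04 log units; within the scatter), set beside the earlier one because a 1.1-fold lower number from compound 2 to compound 1 (0.06 log units; within the scatter) was flat within the scatter. That rests on a single precedent carried across to another core, so the range is kept wide. Compound 4 is expected to give about 19000 nM, with a range from 8000 nM to 45000 nM.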

Compound 4, half-maximal inhibitory concentration: 29000 nM
Beside the measured number, compound 4's estimate is 1.5-fold (0.18 log units) below it; the measured number falls inside the stated range.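

In this assay, the change from 4-chlorophenyl to phenyl on the second core gives a 1.4-fold higher number from compound 3 to compound 4 (0.14 log units; within the scatter), so this core also shows no readable effect of replacing chloro with hydrogen. Set beside the earlier step on the first core, the new step does not differ from it: the same change on two cores in this assay, a 1.1-fold lower number (0.06 log units; within the scatter) from compound 2 to compound 1 and a 1.4-fold higher number (0.14 log units; within the scatter) from compound 3 to compound 4, 1.6-fold (0.20 log units) apart, within the scatter of two such steps. This shows that the change carries from one core to the other in these two pairs without a readable difference, but with both steps flat, it tests only agreement between two near-null results; it does not show that the cores would respond alike to a change with a step beyond the scatter, nor does it compare the two cores themselves.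

From the compounds shown here alone, it remains open whether a methoxy group, a carboxylic acid or a dimethylamino group at the same place, on the six-membered aromatic ring of carbon only, would give a step beyond the scatter on either core. Also open, going by these compounds, is whether replacing the amino group common to all four compounds with a hydroxyl group or an acetamide would shift the numbers, and whether any such shift would carry between the cores.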